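Hydrazone aryl swap: fluorophenyl to methylphenyl in rats

The compounds below may be only part of what the source reports. "The series", "measured", "known", "first", "only" and "open" are said of these compounds alone.

Two compounds of this series have a measurement in a functional assay on the whole organism for inhibition, with Rattus norvegicus as the target; a higher number here means that more compound is needed for the effect, a lower number that less compound is needed. Compound 1, with the structure `CCOC(=O)c1cnc2n(c1=O)C(C)CC/C2=N\Nc1cccc(C(=O)O)c1`, gives 100 umol/kg in this assay. Compound 2, with the structure `CC1CC/C(=N\Nc2ccc(F)cc2)c2ncc(C(=O)O)c(=O)n21`, gives 12.2 umol/kg in this assay. Of the two numbers, that of compound 2 is the lowest; the nearest is compound 1, which sits at a higher number by more than the usual scatter, so compound 2 needs less compound than compound 1 for the same effect.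

Compound 3, with the structure `Cc1cccc(N/N=C2\CCC(C)n3c2ncc(C(=O)O)c3=O)c1`, has not yet been measured in this assay. It differs from compound 2 in one place: 3-methylphenyl in place of 4-fluorophenyl on an amine nitrogen. The aryl group on the amine nitrogen keeps the same count of heavy atoms, with no donor or acceptor added or lost, and the rest of the structure is untouched.

Within the data shown here, no measured pair shows this exact change, so the expectation rests on the closeness of the two structures. Compound 3 is expected to land near compound 2, with a step of a 1.3-fold higher number from compound 2 to compound 3 (0.12 log units; within the scatter) that is not expected to exceed the scatter. The estimate for compound 3 in this assay is 16 umol/kg, with a range from 5 umol/kg to 50 umol/kg.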

Compound 3, dose for 50% inhibition: 0.4 umol/kg
The estimate for compound 3 lay 40-fold (1.60 log units) above the measured number; measured number outside the range, below it.
By their numbers in this assay, from the lowest: compound 3; then compound 2; then compound 1.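

In this assay, the aryl group on the amine nitrogen proves to be a highly sensitive position: replacing 4-fluorophenyl with 3-methylphenyl gives a 31-fold lower number from compound 2 to compound 3 (1.48 log units; beyond the scatter) on a core that is otherwise unchanged. Among these compounds, this is the first step between compounds differing in one place, and it shows that a large change in dose can occur even though both groups have the same count of heavy atoms and neither has a hydrogen-bond donor or acceptor. No measured property is available to account for this step.

The swap exchanges fluorine for methyl and also changes where the substituent sits on the ring, so these compounds cannot show whether the step follows the methyl group itself, its place on the ring, or the two together. Also open, as far as these compounds go, is how an unsubstituted phenyl, a chlorophenyl or a methoxyphenyl on the same amine nitrogen would compare with the 3-methylphenyl group of compound 3.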